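This account rests on a few compounds, and the source may have more. Where it says the series, first, only, none or still open, it means among the compounds named here.

Compound 1 `CSCC[C@H](NC(=O)CN(c1nc(Cl)nc2[nH]cnc12)C1CC1)C(=O)OCc1ccccc1` gives 17.6% in a functional assay on the whole organism (Tail, strain ICR) with Mus musculus as the target, in the tail flick test, with a stated time of 150 min, at a dose of 25 umol/kg by the oral route; on this read-out lower numbers stand for a weaker effect and higher numbers for a stronger effect at the one dose given.
Compound 2 `NC(=O)CC[C@H](NC(=O)CN(c1nc(Cl)nc2[nH]cnc12)C1CC1)C(=O)O` gives 11.4%.
Compound 3 `NC(=O)C[C@H](NC(=O)CN(c1nc(Cl)nc2[nH]cnc12)C1CC1)C(=O)OCc1ccccc1` gives 13.5%.

Compound 3 stands second highest of the three numbers, yet compound 2 and compound 1 both lie within the scatter of it. Compound 4 `NC(=O)CC[C@H](NC(=O)CN(c1nc(Cl)nc2[nH]cnc12)C1CC1)C(=O)OCc1ccccc1` differs from compound 3 by carbamoylmethyl in place of carbamoyl on a saturated chain carbon, two bonds along the chain from an amide-type nitrogen and a carbonyl carbon. Within the data shown here, only one measured step exists, a number 4.1 percentage points lower from compound 1 to compound 3 (within the scatter), and it concerns a different change. Compound 2, which also bears carbamoylmethyl, gives a value within the scatter of compound 3 in this assay. No step beyond the scatter is therefore expected. Compound 4 is estimated at 13%, with a range from 5% to 22%. This amounts to an expected step of a number 0.5 percentage points lower from compound 3 to compound 4 (within the scatter).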

Compound 4, a percentage reported as activity, at one dose (the size of the read-out at that dose, not a potency): 31.1%
Estimate against measurement, compound 4: 18.1 percentage points below; measured number outside the range, above it.
By their numbers in this assay, from the lowest: compounds 2, 3 and 1 (each within the scatter of the next); then compound 4.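

At this saturated chain carbon, chain length matters in this assay: carbamoylmethyl in place of carbamoyl gives a number 17.6 percentage points higher from compound 3 to compound 4 (beyond the scatter). Carbamoyl in place of methylsulfanyl, three bonds along the chain from an amide-type nitrogen and a carbonyl carbon, gives a number 13.5 percentage points higher from compound 1 to compound 4 (beyond the scatter), while benzyl in place of hydrogen on an oxygen next to a carbonyl group gives a number 19.7 percentage points higher from compound 2 to compound 4 (beyond the scatter). Both the side chain and the benzyl ester therefore bear on the read-out at this dose.

No supporting data explain these steps. As far as these compounds go, whether a longer chain, or an amine or a carboxylic acid in place of the carbamoyl, would keep this gain remains open.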